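From pyridin-3-yl to pyridin-2-yl on a carbonyl carbon

The compounds below may be only part of what the source reports. "The series", "measured", "known", "first", "only" and "open" are said of these compounds alone.

Among the compounds with values here, in a functional assay on RAW264.7 cells (Mus musculus) for inhibition (a lower number here means a stronger inhibitor, a higher number a weaker inhibitor), compound 1 `O=C(NS(=O)(=O)c1ccccc1)c1cccnc1` gives 9500 nM and compound 2 `Cc1ccc(S(=O)(=O)NC(=O)c2cccnc2)cc1` gives 8800 nM, so compound 1 stands level with its only neighbour, within the scatter. Compound 3 `O=C(NS(=O)(=O)c1ccccc1)c1ccccn1` carries pyridin-2-yl in place of pyridin-3-yl on a carbonyl carbon. Within the data shown here, the only measured step, a 1.1-fold lower number from compound 1 to compound 2 (0.03 log units; within the scatter), is a different change, methyl in place of hydrogen on an aromatic carbon, so it offers only weak guidance. No step beyond the scatter is expected in this assay, though the data cannot exclude one. The estimated step is a 1.1-fold higher number from compound 1 to compound 3 (0.02 log units; within the scatter). For compound 3 the expected value is 10000 nM, with an estimated range of 3000 nM to 30000 nM.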

Compound 3, half-maximal inhibitory concentration: 4500 nM
For compound 3 the middle estimate is 2.2-fold (0.35 log units) above the measured one, within the range that was stated.
By their numbers in this assay, from the lowest: compounds 3, 2 and 1 (each within the scatter of the next, the first and the last beyond it).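

In this assay the change to pyridin-2-yl in place of pyridin-3-yl on a carbonyl carbon gives a 2.1-fold lower number from compound 1 to compound 3 (0.32 log units; beyond the scatter) and this modest step lies beyond the scatter. The earlier pair showed only a methyl change that stayed within the scatter, whereas here the same atoms joined differently shift the number. Nothing measured here accounts for this step.

As far as these compounds go, whether pyridin-4-yl at this carbonyl carbon would lower the number further remains open. So does whether methyl on the other ring would combine with pyridin-2-yl.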